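Replacing Propanoyl with Butyl on the Phenol Oxygen

The source may report more compounds than this note shows. Statements on the series, on what has been measured and on what is new or still open speak of the compounds shown alone.

Compound 3 `C=CCc1cc(OC(=O)CC)ccc1OCCCNC(C)C` gives 0.05 nM in an assay for inhibition of squalene synthase (Rattus norvegicus), using microsomes (on this read-out higher numbers stand for weaker inhibition and lower numbers for stronger inhibition), the lowest of the three numbers recorded. Compound 1 `CCCCOc1ccc(OCCCNC(C)C)cc1` gives 56 nM and compound 2 `C=CCc1ccccc1OCCCNC(C)C` gives 56 nM in this assay. Within the data shown here, the only single-place step measured, a 1100-fold lower number from compound 2 to compound 3 (3.05 log units; beyond the scatter), shows what the propanoyloxy group brought. Compound 4 `C=CCc1cc(OCCCC)ccc1OCCCNC(C)C` carries butyl in place of propanoyl on an oxygen on an aromatic ring. Among the measured compounds shown here, no measured step covers this exchange directly; compound 1, which also bears a butoxy group but lacks the allyl group, shows a much higher number than compound 3. Compound 4 is therefore expected to keep part of the gain over compound 2 but to give up some of it, an estimated 30-fold higher number from compound 3 to compound 4 (1.48 log units; beyond the scatter). The estimate for compound 4 is 1.5 nM, within 0.1 nM to 20 nM.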

Compound 4, half-maximal inhibitory concentration: 0.6 nM
Compound 4: the middle estimate sits 2.5-fold (0.40 log units) above what was measured; the measured number falls inside the stated range.
By their numbers in this assay, from the lowest: compound 3; then compound 4; then compounds 1 and 2 (each within the scatter of the next).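

In this assay the carbonyl of propanoyl is not required for a low number at this oxygen on the aromatic ring: butoxy retains much of the gain, with a 93-fold lower number from compound 2 to compound 4 (1.97 log units; beyond the scatter) as the step, although a 12-fold higher number from compound 3 to compound 4 (1.08 log units; beyond the scatter) shows that the exchange still has a large cost. The allyl group also counts alongside butoxy, as a 93-fold lower number from compound 1 to compound 4 (1.97 log units; beyond the scatter) is a large step on its own. Nothing available explains the difference between propanoyloxy and butoxy at this position.

The compounds shown leave open how a shorter or longer chain, such as methoxy or hexyloxy, would read at this oxygen. They also leave open whether an amide or a carboxylic acid could stand in place of the propanoyloxy group.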